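The compounds below may be only part of what the source reports. "The series", "measured", "known", "first", "only" and "open" are said of these compounds alone.

Measured in an ADME assay on L02 cells (Homo sapiens) for cytotoxicity, read by MTT assay, with a stated time of 24 h; on this read-out higher numbers stand for weaker inhibition and lower numbers for stronger inhibition:
compound 1 `CN1C/C(=C\c2cccnc2)C(=O)/C(=C/c2ccc(F)cc2Br)C1` gives 14400 nM
compound 2 `CN1C/C(=C\c2ccncc2)C(=O)/C(=C/c2ccc(F)cc2Br)C1` gives 12400 nM
compound 3 `O=C1/C(=C/c2cccnc2)CNC/C1=C\c1ccccc1F` gives 15900 nM

Compound 1 and compound 2 share a core and differ by pyridin-4-yl in place of pyridin-3-yl on a double-bonded chain carbon bound to a double-bonded ring carbon; the step is a 1.2-fold lower number from compound 1 to compound 2 (0.06 log units; within the scatter). Compound 3 is built on another core; the difference between the two cores is not broken down here. Its number lies within the scatter of both compound 1 and compound 2, so the three numbers are not told apart.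

Compound 4 `O=C1/C(=C/c2ccncc2)CNC/C1=C\c1ccccc1F` has not yet been measured in this assay. It differs from compound 3 by pyridin-4-yl in place of pyridin-3-yl on a double-bonded chain carbon bound to a double-bonded ring carbon, the same change as between compound 1 and compound 2. For compound 4 the step is expected to be a 1.1-fold lower number from compound 3 to compound 4 (0.06 log units; within the scatter) because the same change gave a 1.2-fold lower number from compound 1 to compound 2 (0.06 log units; within the scatter) on the other core. Compound 4 is therefore estimated at 14000 nM, with a range from 8000 nM to 25000 nM.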

Compound 4, half-maximal inhibitory concentration: 14700 nM
The estimate for compound 4 lay 1.1-fold (0.02 log units) below the measured number, and the stated range covers the measured number.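

In this assay, pyridin-4-yl in place of pyridin-3-yl on a double-bonded chain carbon bound to a double-bonded ring carbon gives a 1.1-fold lower number from compound 3 to compound 4 (0.03 log units; within the scatter) on the core of compound 3. The change reads alike on both cores: the same change on two cores in this assay, a 1.2-fold lower number (0.06 log units; within the scatter) from compound 1 to compound 2 and a 1.1-fold lower number (0.03 log units; within the scatter) from compound 3 to compound 4, 1.1-fold (0.03 log units) apart, within the scatter of two such steps. This shows that the change carries from one core to the other without a shift that can be told from the scatter, but it does not show that the change has any effect of its own on this read-out, or that the two cores would respond alike to a change that moves the number.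

The compounds shown carry only pyridin-3-yl and pyridin-4-yl at this place. Going by these compounds, what a phenyl ring or a carboxylic acid there would do to the number remains open.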